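The source may report more compounds than this note shows. Statements on the series, on what has been measured and on what is new or still open speak of the compounds shown alone.

Values so far in an ADME assay on MDCKII-LE cells (Canis lupus familiaris) for permeability (a higher number here means that the compound crosses the layer faster, a lower number that the compound crosses the layer more slowly), as measured:
- compound 1 `N#CCCN([C@H](CCC(F)(F)F)C(N)=O)S(=O)(=O)c1ccc(Cl)cc1` gives 10.2 10^-6 cm/s
- compound 2 `N#C[C@H]1C[C@@H](CN([C@H](CCC(F)(F)F)C(N)=O)S(=O)(=O)c2ccc(Cl)cc2)C1` gives 24.1 10^-6 cm/s
- compound 3 `N#C[C@H]1C[C@H](CN([C@H](CCC(F)(F)F)C(N)=O)S(=O)(=O)c2ccc(Cl)cc2)C1` not yet measured

For the measured compounds named here, compound 2 holds the higher of the two numbers at 24.1 10^-6 cm/s and its only neighbour is compound 1 at 10.2 10^-6 cm/s on the lower side.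

The next comparison is purely one of configuration: the two compounds have the same atoms and bonds and differ only in configuration as drawn: 2 of 3 stereo elements differ; a stereocentre at a saturated ring carbon is drawn S in compound 2 and R in compound 3; a stereocentre at a saturated ring carbon is drawn s in compound 2 and r in compound 3. Going by the values given here, only one measured step exists, a 2.4-fold higher number from compound 1 to compound 2 (0.37 log units; beyond the scatter), a modest step beyond the scatter in this assay that replaces cyanomethyl with 3-cyanocyclobutyl. That step changes the group itself, so it bears on the present question only indirectly. Among the compounds with values here, no measured pair differs in configuration alone, which leaves the direction open and the size poorly constrained.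

With no evidence for a shift either way, no step beyond the scatter is expected, and the middle of the estimate stays close to compound 2. The expected change is a 1.1-fold lower number from compound 2 to compound 3 (0.04 log units; within the scatter) with no direction favoured. Compound 3 is estimated at 22 10^-6 cm/s with an expected range from 11 10^-6 cm/s to 40 10^-6 cm/s in this series.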

Compound 3, apparent permeability: 24.9 10^-6 cm/s
For compound 3 the middle estimate is 1.1-fold (0.05 log units) below the measured one; measured number inside the range.
By their numbers in this assay, from the lowest: compound 1; then compounds 2 and 3 (each within the scatter of the next).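

In this assay, the series now holds a pair that isolates configuration at the 3-cyanocyclobutyl group, and it gives a 1.0-fold higher number from compound 2 to compound 3 (0.01 log units; within the scatter). The higher number seen with 3-cyanocyclobutyl in place of cyanomethyl is therefore not confined to one drawn configuration: alongside a 2.4-fold higher number from compound 1 to compound 2 (0.37 log units; beyond the scatter), the other form gives a 2.4-fold higher number from compound 1 to compound 3 (0.39 log units; beyond the scatter), so both stand beyond the scatter of compound 1. The pair reads directly on configuration at these two saturated ring carbons, with no change of group mixed in: the fact that compounds 2 and 3 differ only in the configuration as drawn.

The compounds shown leave open whether the step from cyanomethyl follows the cyclobutyl ring or the nitrile on it, a question that an unsubstituted cyclobutyl or a 3-hydroxycyclobutyl group would help to separate. They also leave open whether configuration stays equally silent in this assay with a different group on the ring, such as an amine or a carboxylic acid, or at the third stereo element, which is drawn alike in compound 2 and compound 3.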